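This account rests on a few compounds, and the source may have more. Where it says the series, first, only, none or still open, it means among the compounds named here.

Compound 2, `CS(=O)(=O)N(CCCCCCN1C[C@H](O)[C@@H](O)[C@H](O)[C@H]1CO)C1CCCCC1`, is the starting point, and in an ADME assay on Huh-7 cells (Homo sapiens) for cytotoxicity, read by MTT assay (a lower number here means that less compound is tolerated, a higher number that more compound is tolerated), compound 2 gives > 500000 nM, which is a limit of the assay rather than a measured number. Its companion compound 1, `O=C(c1ccccc1)N(CCCCCCN1C[C@H](O)[C@@H](O)[C@H](O)[C@H]1CO)C1CCCCC1`, gives > 500000 nM in this assay, again a limit. Within the data shown here, compound 3, `O=S(=O)(c1ccccc1)N(CCCCCCN1C[C@H](O)[C@@H](O)[C@H](O)[C@H]1CO)C1CCCCC1`, is the only member of the set with a number, giving 280000 nM in this assay. Among the measured steps, a step that the two limits leave unreadable from compound 1 to compound 2, while an at least 1.7-fold lower number from compound 1 to compound 3 (0.25 log units; that floor lies within the scatter) and an at least 1.7-fold lower number from compound 2 to compound 3 (0.25 log units; that floor lies within the scatter), each of these last two resting on a floor that lies within the scatter. The unmeasured compound 4, `NC(=O)N(CCCCCCN1C[C@H](O)[C@@H](O)[C@H](O)[C@H]1CO)C1CCCCC1`, differs from compound 2 by carbamoyl in place of methylsulfonyl on an amine nitrogen. Among the measured compounds shown here, no measured step exchanges a sulfonyl for a carbamoyl, so none bears directly on this change; the only guidance is the limit of > 500000 nM in this assay, at which 2 of the 3 values shown sit, which gives no sign of a drop in this assay from compound 2. Compound 4 is therefore expected to sit near the limit again, with a step of a number no higher from compound 2 to compound 4 (the limit leaves the size open). The estimate for compound 4 in this assay is 500000 nM, within a range from 250000 nM to 1000000 nM.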

Compound 4, half-maximal cytotoxic concentration: > 500000 nM
Compound 4: only a limit was reported (the forecaster's own chance of this, stated with the estimate: 75%); the middle value sits exactly at the limit.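

In this assay, among these compounds, the carbamoyl group on the amine nitrogen leaves compound 4 at a limit rather than a number, so carbamoyl joins benzoyl and methylsulfonyl there, and phenylsulfonyl in compound 3 remains the only group with a number: the limit of > 500000 nM in this assay, at which 3 of the 4 values shown sit. Among the compounds shown here, the one readable comparison is an at least 1.7-fold higher number from compound 3 to compound 4 (0.25 log units; that floor lies within the scatter), so it does not firmly set the phenylsulfonyl group apart. The steps from compound 1 and from compound 2 to compound 4 have limits at both ends and cannot be read.

From the compounds shown here alone, the order among compound 1, compound 2 and compound 4 stays open, as all three rest on limits. Also open, going by these compounds, is whether an aminoacetyl group or a carboxylic acid carried on this amine nitrogen would give a number in this assay.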